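From Ethyl to Cyclopentylmethyl on the Shared Core

The source may report more compounds than this note shows. Statements on the series, on what has been measured and on what is new or still open speak of the compounds shown alone.

Measured in a functional assay on HL-60 cells (Homo sapiens) for inhibition; on this read-out lower numbers stand for stronger inhibition and higher numbers for weaker inhibition:
Compound 1 `COc1ccc(-c2cc(=O)n(Cc3cccnc3)nc2-c2ccc(OC)cc2)cc1`: 430 nM
Compound 2 `CCn1nc(-c2ccc(OC)cc2)c(-c2ccc(OC)cc2)cc1=O`: 610 nM
Compound 3 `COc1ccc(-c2cc(=O)n(C3CC3)nc2-c2ccc(OC)cc2)cc1`: 7980 nM

Compound 2 sits near compound 1 and far from compound 3: a 1.4-fold higher number from compound 1 to compound 2 (0.15 log units; within the scatter), yet a 13-fold higher number from compound 2 to compound 3 (1.12 log units; beyond the scatter). Compound 4 `COc1ccc(-c2cc(=O)n(CC3CCCC3)nc2-c2ccc(OC)cc2)cc1` differs from compound 2 by cyclopentyl in place of methyl on a saturated chain carbon bound to an aromatic nitrogen. The small step bears most directly, since it changes a group at that same chain carbon. The large steps, also a 19-fold higher number from compound 1 to compound 3 (1.27 log units; beyond the scatter), put cyclopropyl on the aromatic nitrogen, which compound 4 does not have. No step beyond the scatter is therefore expected in this assay. The estimated step is a 1.2-fold lower number from compound 2 to compound 4 (0.09 log units; within the scatter). For compound 4 the expected value is 500 nM, with an estimated range of 150 nM to 1800 nM.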

Compound 4, half-maximal inhibitory concentration: 110 nM
For compound 4 the middle estimate is 4.5-fold (0.66 log units) above the measured one, outside the stated range (below it).
By their numbers in this assay, from the lowest: compound 4; then compounds 1 and 2 (each within the scatter of the next); then compound 3.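

Cyclopentyl in place of methyl on the saturated chain carbon bound to an aromatic nitrogen gives a 5.5-fold lower number from compound 2 to compound 4 (0.74 log units; beyond the scatter) and is thus the first change at this carbon to go beyond the scatter. The same carbon also separates cyclopentyl from pyridin-3-yl, with a 3.9-fold lower number from compound 1 to compound 4 (0.59 log units; beyond the scatter) showing that these two ring groups are not interchangeable there. Cyclopentylmethyl in place of cyclopropyl on the aromatic nitrogen gives a 73-fold lower number from compound 3 to compound 4 (1.86 log units; beyond the scatter) as the largest step in the set, leaving compound 4 with the lowest number of the four.

As far as these compounds go, whether cyclohexyl, phenyl or an open butyl chain at this carbon would match cyclopentyl remains open. No measurement shown explains these differences.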